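A few compounds are considered here, and "the series" means these few. Any claim that something is new, unique, unknown or untested is made for them only; others in the source may bear on it.

Measured so far in an assay on isolated protein for displacement of a labelled ligand from metabotropic glutamate receptor 5 (Homo sapiens), with a stated time of 60 min, tested at 1 uM; a higher number here means more inhibition at the concentration tested (going by the name of the read-out), a lower number less inhibition:
Compound 1 `CC1CCN(c2c(S(=O)(=O)c3cccc(Cl)c3)cnc3ccc(Cl)cc23)CC1` gives 92%.
Compound 2 `Cc1ccc(S(=O)(=O)c2cnc3ccc(Cl)cc3c2N2CCC(C)CC2)cc1Cl` gives 81%.
Compound 3 `CC1CCN(c2c(S(=O)(=O)c3cc(F)cc(F)c3)cnc3ccc(Cl)cc23)CC1` gives 93%.

Compound 3 has the highest number of the three, but its separation from compound 1 is only a number 1 percentage points higher from compound 1 to compound 3 (within the scatter), which lies within the scatter, so the two cannot be ranked. Its separation from compound 2 is a number 12 percentage points higher from compound 2 to compound 3 (beyond the scatter), which lies beyond the scatter. The remaining step, a number 11 percentage points lower from compound 1 to compound 2 (beyond the scatter), concerns a different place on the ring attached to the sulfonyl sulfur.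

Compound 4 is `CC1CCN(c2c(S(=O)(=O)c3cccc(C#N)c3)cnc3ccc(Cl)cc23)CC1`. It differs from compound 3 only at the sulfonyl sulfur: 3-cyanophenyl in place of 3,5-difluorophenyl on a sulfonyl sulfur.

The two steps that bear on this change are those that also swapped the ring on the sulfonyl sulfur: a number 1 percentage points higher from compound 1 to compound 3 (within the scatter) and a number 12 percentage points higher from compound 2 to compound 3 (beyond the scatter). Neither moved the number far, and three different rings at this place all gave high inhibition. The step from compound 3 to compound 4 in this assay is therefore expected to be small or within the scatter, estimated as a number 5 percentage points lower from compound 3 to compound 4 (within the scatter). Compound 4 is expected to give about 88%, with a likely range from 76% to 97%.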

Compound 4, a percentage reported as inhibition, at one concentration (the size of the read-out at that concentration, not a potency): 90%
The estimate for compound 4 lay 2 percentage points below the measured number; the range from low to high includes it.
By their numbers in this assay, from the lowest: compounds 2, 4, 1 and 3 (each within the scatter of the next, the first and the last beyond it).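

In this assay, a ring carrying a nitrile does as well at this place on the sulfonyl sulfur as the halogen-bearing rings: the change from 3,5-difluorophenyl to 3-cyanophenyl gives a number 3 percentage points lower from compound 3 to compound 4 (within the scatter) and the swap of cyano for chloro gives a number 2 percentage points lower from compound 1 to compound 4 (within the scatter) in the same read-out. The replacement of 3-chloro-4-methylphenyl by 3-cyanophenyl gives a number 9 percentage points higher from compound 2 to compound 4 (within the scatter) and so does not separate these two compounds either, which leaves compound 4 unranked against all three earlier compounds. Nothing measured here goes beyond these inhibition numbers to account for them.

These numbers come from a single concentration and so do not show how potency compares across the rings. Going by these compounds, whether a ring carrying an amine or a carboxylic acid, or a saturated cyclohexyl group on the sulfonyl sulfur, would keep this level of inhibition remains open.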